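A few compounds are considered here, and "the series" means these few. Any claim that something is new, unique, unknown or untested is made for them only; others in the source may bear on it.

Measured compounds in a functional assay on HeLa cells (Homo sapiens) for cytotoxicity, in the presence of a further agent that is not named here; on this read-out higher numbers stand for weaker inhibition and lower numbers for stronger inhibition:
compound 1 `Clc1ccc(-c2cc(-c3cccnc3)nc(-c3ccsc3)c2)o1` gives a limit, > 50000 nM
compound 2 `Clc1ccc(-c2cc(-c3cccs3)nc(-c3ccccc3Cl)c2)o1` gives 18500 nM
compound 3 `Clc1ccc(-c2cc(-c3cccnc3)nc(-c3cccs3)c2)o1` gives 14600 nM

Compound 1 is known only by a limit, (the limit of > 50000 nM in this assay, at which 1 of the 3 values shown sits), so its place among the numbers is at the weak end of the range shown. Compound 4 `Cc1cccc(-c2cc(-c3ccc(Cl)o3)cc(-c3ccsc3)n2)c1` differs from compound 1 in one place: 3-methylphenyl in place of pyridin-3-yl on an aromatic carbon. The step that bears on this change is the swap of aryl groups at the same position, a 1.3-fold lower number from compound 2 to compound 3 (0.10 log units; within the scatter), which did not move the number beyond the scatter. The other step, an at least 3.4-fold lower number from compound 1 to compound 3 (0.53 log units; beyond the scatter), concerns a different position. Accordingly compound 4 is expected to show no change beyond the scatter, a number no higher from compound 1 to compound 4 (the limit leaves the size open), and most likely to return a limit again. Compound 4 is estimated at 50000 nM, within 15000 nM to 150000 nM.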

Compound 4, half-maximal inhibitory concentration: 20300 nM
Compound 4: the middle estimate sits 2.5-fold (0.39 log units) above what was measured, and the stated range covers the measured number.
By their numbers in this assay, from the lowest: compounds 3, 2 and 4 (each within the scatter of the next). At a limit, above all of these: compound 1.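

With the thiophen-3-yl group in place, 3-methylphenyl in place of pyridin-3-yl next to the ring nitrogen gives an at least 2.4-fold lower number from compound 1 to compound 4 (0.39 log units; beyond the scatter), so a change at this position can reach beyond the scatter in this assay, unlike a 1.3-fold lower number from compound 2 to compound 3 (0.10 log units; within the scatter). From the compounds shown here alone, compound 1 stands at a limit, so the size of this step stays open: the limit of > 50000 nM in this assay, at which 1 of the 4 values shown sits.

The compounds shown do not separate the methyl from the loss of the ring nitrogen. Going by these compounds, how an amine or a carboxylic acid at this position would read also stays open.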